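The compounds below may be only part of what the source reports. "The series", "measured", "known", "first", "only" and "open" are said of these compounds alone.

Measured so far in a functional assay on the whole organism for inhibition, with Rattus norvegicus as the target, at a dose of 30 mg/kg; on this read-out higher numbers stand for more inhibition at the one dose given (going by the name of the read-out) and lower numbers for less inhibition:
compound 1 `Cc1ccc(-c2nc3cccnc3o2)cc1`, 0%
compound 2 `c1ccc(-c2nc3cccnc3o2)cc1`, 55%

In this assay compound 2 gives 55%, the higher of the two numbers; compound 1 gives 0%. Compound 3 `COc1cccc(-c2nc3cccnc3o2)c1` carries methoxy in place of hydrogen on an aromatic carbon. Going by the values given here, only one measured step bears on this: a number 55 percentage points higher from compound 1 to compound 2 (beyond the scatter), a large loss on adding a methyl to the six-membered aromatic ring of carbon only. Methoxy is a different group at a different place, so that step is only a loose guide, but some drop from compound 2 is expected. Compound 3 is therefore estimated at 25%, range 0% to 60%, which means an expected step of a number 30 percentage points lower from compound 2 to compound 3 (beyond the scatter).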

Compound 3, a percentage reported as inhibition, in the whole organism at one dose (the size of the read-out at that dose, not a potency): 0%
Compound 3: middle estimate off by 25 percentage points, on the high side, within the range that was stated.
By their numbers in this assay, from the lowest: compounds 1 and 3 (each within the scatter of the next); then compound 2.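

Methoxy on an aromatic carbon of the six-membered aromatic ring of carbon only, meta to a group of 9 heavy atoms, gives a number 55 percentage points lower from compound 2 to compound 3 (beyond the scatter) in this assay at the one dose. The earlier step concerned methyl, so this adds a second, oxygen-linked group on the same ring whose introduction also leaves compound 3 at 0% with no inhibition to read. Nothing available explains this loss.

Still open, from the compounds shown here alone, is whether fluorine or an amine at this place keeps any inhibition. Methoxy at another carbon of this ring also remains open.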